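Para-fluoro substitution on the benzylsulfanyl arm of a triazole series

This account rests on a few compounds, and the source may have more. Where it says the series, first, only, none or still open, it means among the compounds named here.

Compound 1 `c1ccc(CSc2nnc(-c3ccc4c(c3)OCCO4)n2-c2ccccc2)cc1` is the parent of a small set sharing one core, with a benzyl group on the sulfur. In a functional assay on HeLa cells (Homo sapiens) for antiproliferative activity, read by MTT assay, with a stated time of 24 h (on this read-out lower numbers stand for stronger inhibition and higher numbers for weaker inhibition), compound 1 gives 32800 nM. Compound 2 `Cc1ccccc1CSc1nnc(-c2ccc3c(c2)OCCO3)n1-c1ccccc1`, which carries a methyl in place of hydrogen on an aromatic carbon, gives 36000 nM in this assay, and compound 3 `Cc1ccc(CSc2nnc(-c3ccc4c(c3)OCCO4)n2-c2ccccc2)cc1`, with a methyl at another aromatic carbon, gives 49700 nM. The three numbers sit in a narrow band: a 1.1-fold higher number from compound 1 to compound 2 (0.04 log units; within the scatter), a 1.5-fold higher number from compound 1 to compound 3 (0.18 log units; within the scatter) and a 1.4-fold higher number from compound 2 to compound 3 (0.14 log units; within the scatter) all fall within the scatter, so compound 1 cannot be set apart from either neighbour.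

Compound 4 `Fc1ccc(CSc2nnc(-c3ccc4c(c3)OCCO4)n2-c2ccccc2)cc1` differs from compound 1 by fluoro in place of hydrogen on an aromatic carbon. Among the measured compounds shown here, the only comparable steps, those adding a methyl to the same benzyl ring in compound 2 and compound 3, left this assay essentially unchanged, so a small substituent on that ring is expected to do the same here, with no step beyond the scatter. Compound 4 is therefore estimated at 38000 nM in this assay, within 20000 nM to 75000 nM, which corresponds to an expected 1.2-fold higher number from compound 1 to compound 4 (0.06 log units; within the scatter).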

Compound 4, half-maximal inhibitory concentration: 46900 nM
Compound 4: the middle estimate sits 1.2-fold (0.09 log units) below what was measured, within the range that was stated.
By their numbers in this assay, from the lowest: compounds 1, 2, 4 and 3 (each within the scatter of the next).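

Fluoro is the first substituent on this ring that is not a carbon group, and on the aromatic carbon para to a large group it gives a 1.4-fold higher number from compound 1 to compound 4 (0.16 log units; within the scatter) in this assay. Fluoro in place of the methyl at that carbon gives a 1.1-fold lower number from compound 3 to compound 4 (0.03 log units; within the scatter), and the 4-fluorophenyl in place of the 2-methylphenyl gives a 1.3-fold higher number from compound 2 to compound 4 (0.11 log units; within the scatter), so this position has now accepted both a methyl and a fluoro with every step staying within the scatter. Nothing available here offers an explanation for this flat result.

Going by these compounds, whether any group on this ring can move the number beyond the scatter remains open, and a methoxy, an amine or a carboxylic acid would be a stronger test of that. The shared core also stays fixed throughout, and so does the single benzyl carbon on the sulfur, leaving the effect of a longer chain there unknown.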